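Swapping the benzyl group of compound 1

The source may report more compounds than this note shows. Statements on the series, on what has been measured and on what is new or still open speak of the compounds shown alone.

In a functional assay on aorta (Rattus norvegicus, strain Sprague-Dawley) (a higher number here means that more compound is needed for the effect, a lower number that less compound is needed), compound 1 `Cc1ccccc1COc1nc2c(cc1-c1nc(N)cc(N)n1)c(C)nn2-c1ccccc1` gives 290 nM. Compound 2 `Cc1nn(-c2ccccc2)c2nc(OCc3ccccc3F)c(-c3nc(N)c(N4CCCCC4)c(N)n3)cc12` gives 790 nM, which leaves compound 1 with the lower of these two numbers. Compound 3 `Cc1nn(-c2ccccc2)c2nc(OCc3ccccc3F)c(-c3nc(N)c(NC(=O)OC4CCCC4)c(N)n3)cc12` reports only a limit, > 100000 nM.

Compound 4 `Cc1nn(-c2ccccc2)c2nc(OCc3ccc(C(F)(F)F)cc3)c(-c3nc(N)cc(N)n3)cc12` keeps the core of compound 1 and exchanges one group: 4-(trifluoromethyl)phenyl in place of 2-methylphenyl on a saturated chain carbon bound to an oxygen on an aromatic ring. In words, 2-methylbenzyl gives way to 4-(trifluoromethyl)benzyl, with the change sitting on a saturated chain carbon bound to an oxygen on an aromatic ring.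

Among the compounds with values here, the only measured step is large: an at least 120-fold higher number from compound 2 to compound 3 (2.10 log units; beyond the scatter). It replaces piperidin-1-yl with (cyclopentyloxycarbonyl)amino, however, and leaves the benzyl group alone, so it bears on this change hardly at all. Within the data shown here, no measured step covers the new group, so the expectation stays near compound 1 at 290 nM, and only a modest rise in the number is expected. The expected step is a 2.1-fold higher number from compound 1 to compound 4 (0.32 log units; beyond the scatter). In this assay, compound 4 is estimated at 600 nM, with an expected range from 120 nM to 3000 nM.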

Compound 4, half-maximal effective concentration: 1600 nM
Compound 4: the middle estimate sits 2.7-fold (0.43 log units) below what was measured; low and high end bracket the measured number.
By their numbers in this assay, from the lowest: compound 1; then compound 2; then compound 4. At a limit, above all of these: compound 3.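

Within the data shown here, this is the first measured step at this position, and it shows that the group on the saturated chain carbon matters when the rest of compound 1 stays the same: 4-(trifluoromethyl)phenyl in place of 2-methylphenyl gives a 5.5-fold higher number from compound 1 to compound 4 (0.74 log units; beyond the scatter). The step is modest, and compound 4 still gives a measured number in this assay rather than a limit, so this position accepts the larger group at some cost. Nothing measured here accounts for the rise in the number.

The exchange alters both the group on the ring and where the name places it, so this one step cannot separate the two. A 4-methylbenzyl or 2-(trifluoromethyl)benzyl group would pull them apart, and an unsubstituted benzyl group would show what either substituent contributes.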